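The source may hold more compounds than are shown below. What is called first, only, known or untested is meant among the compounds shown, and "the series" means these compounds.

Going by the values given here, in a functional assay on the whole organism (strain Albino Swiss CD1) with Mus musculus as the target (a lower number here means that less compound is needed, a higher number that more compound is needed for the effect), compound 2 `CCC(C(=O)NCc1cccc(Cl)c1)N1C(=O)CCC1=O` gives 78.9 mg/kg, and this is the only number the series has produced so far. Among the compounds with values here, compound 1 `CC(C(=O)NCc1cccc(C(F)(F)F)c1)N1C(=O)CCC1=O` carries no result in this assay ("not determined" (no result reported)), so compound 2 stands alone and no step between two measured compounds can be drawn from the data in hand. Compound 3 `CCC(C(=O)NCc1cccc(C(F)(F)F)c1)N1C(=O)CCC1=O` is the next entry to be measured. It differs from compound 2 in one place: trifluoromethyl in place of chloro on an aromatic carbon. Within the data shown here, no measured pair shows what this exchange does in this assay, and compound 1, the entry that carries the trifluoromethyl, offers no number to lean on. The expected step of a 1.0-fold higher number from compound 2 to compound 3 (0.01 log units; within the scatter) is therefore small, within the usual scatter of the read-out, with no firm direction. Compound 3 is accordingly estimated at 80 mg/kg in this assay, with an expected range from 35 mg/kg to 180 mg/kg that leaves room for a shift either way once the dose for half-maximal effect is known.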

Compound 3, dose for half-maximal effect: 77.4 mg/kg
The estimate for compound 3 lay 1.0-fold (0.01 log units) above the measured number, within the range that was stated.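

In this assay the series now has its first readable pair: trifluoromethyl in place of chloro on an aromatic carbon, meta to a large group, gives a 1.0-fold lower number from compound 2 to compound 3 (0.01 log units; within the scatter) and so no separation between the two compounds. At this position of the shared core, a group of 4 heavy atoms (1 carbon, 3 fluorine) stands in for a single chlorine with no change in the dose for half-maximal effect that this pair can show, a finding that holds for these two groups only. No measured property of either compound accompanies this result, and the pair by itself offers no account of it.

Going by these compounds, whether this position accepts groups of other kinds, such as an amine, a carboxylic acid or a methoxy group, remains open, as does the effect of moving trifluoromethyl to another place on the same ring. Steps involving compound 1 cannot be read, so the effect of changing the alkyl chain on the core, whether to a shorter or a longer chain, also remains open.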